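Two Compounds at the Limit, and a Third Awaited

The source may report more compounds than this note shows. Statements on the series, on what has been measured and on what is new or still open speak of the compounds shown alone.

Measured in an ADME assay on Vero cells (Chlorocebus sabaeus) for cytotoxicity, read by MTT assay, with a stated time of 48 h; a higher number here means a weaker inhibitor, a lower number a stronger inhibitor:
Compound 1 `O=c1cc(N2CCN(CC3CCC(OS(=O)(=O)c4cccnc4)CC3)CC2)sc2c([N+](=O)[O-])cc(C(F)(F)F)cc12`: > 64 ug/mL (a limit)
Compound 2 `O=C(OC1CCC(CN2CCN(c3cc(=O)c4cc(C(F)(F)F)cc([N+](=O)[O-])c4s3)CC2)CC1)c1ccc(C(F)(F)F)cc1`: > 64 ug/mL (a limit)

In this assay, compound 2 stands at > 64 ug/mL, which is a limit of the assay and not a number. Among the measured compounds shown here, the same holds for the only other compound measured so far: the limit of > 64 ug/mL in this assay, at which 2 of the 2 values shown sit.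

Compound 3 `O=c1cc(N2CCN(CC3CCC(OS(=O)(=O)c4ccc5c(c4)CCO5)CC3)CC2)sc2c([N+](=O)[O-])cc(C(F)(F)F)cc12` keeps the rest of compound 2 and changes one group, on an oxygen on a saturated carbon: a group of 12 heavy atoms (8 carbon, 3 oxygen, 1 sulfur; one five-membered non-aromatic ring with 1 hetero atom, one six-membered aromatic ring of carbon only) in place of a group of 12 heavy atoms (8 carbon, 1 oxygen, 3 fluorine; one six-membered aromatic ring of carbon only), on an oxygen on a saturated carbon. For the measured compounds named here, the one measured step bearing on this change falls at the same place: a step that the two limits leave unreadable from compound 1 to compound 2. Its size cannot be read, so it offers no measured effect to carry over. What it does show is that compound 1 and compound 2, with different groups on that oxygen, both end at the limit. On that basis, compound 3 is expected to behave alike, most likely reported as a limit again. No step beyond the scatter is expected, and the estimated step is a number no higher from compound 2 to compound 3 (the limit leaves the size open). For compound 3 the estimate is 64 ug/mL, with an expected range of 32 ug/mL to 128 ug/mL.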

Compound 3, half-maximal inhibitory concentration: > 64 ug/mL
Compound 3 gave a limit, no number; the forecaster's own chance of this, stated with the estimate: 80%; the middle value sits exactly at the limit.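

In this assay compound 3 gives > 64 ug/mL, which is a limit of the assay and not a number. Among the compounds shown here, no step among compound 1, compound 2 and compound 3 can be read, and all three share one result: the limit of > 64 ug/mL in this assay, at which 3 of the 3 values shown sit. The compounds shown leave open how these three groups on the oxygen differ, if at all, in this assay.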